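Methyl on the carbon next the amine across the dioxolane series

A few compounds are considered here, and "the series" means these few. Any claim that something is new, unique, unknown or untested is made for them only; others in the source may bear on it.

Of the compounds shown here, three sharing one core have been measured in a functional assay (brain) for displacement of a labelled ligand, with Rattus norvegicus as the target; on this read-out lower numbers stand for stronger inhibition and higher numbers for weaker inhibition. Compound 1 `NC[C@H]1COC(c2ccccc2)(c2ccccc2)O1` gives 1400 nM in this assay. Compound 2 `C[C@H](N)[C@H]1COC(c2ccccc2)(c2ccccc2)O1` gives 607 nM in this assay. Compound 3 `CNC[C@H]1COC(c2ccccc2)(c2ccccc2)O1` gives 7300 nM in this assay, the highest number of the three.

The change from compound 1 to compound 2 is methyl in place of hydrogen on a saturated chain carbon bound to an amine nitrogen and a saturated ring carbon and made a 2.3-fold lower number from compound 1 to compound 2 (0.36 log units; beyond the scatter). The change from compound 1 to compound 3 is methyl in place of hydrogen on an amine nitrogen and made a 5.2-fold higher number from compound 1 to compound 3 (0.72 log units; beyond the scatter). Between compound 2 and compound 3 the step is a 12-fold higher number from compound 2 to compound 3 (1.08 log units; beyond the scatter).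

Compound 4 `CN[C@@H](C)[C@H]1COC(c2ccccc2)(c2ccccc2)O1` has not been measured in this assay. It differs from compound 3 by methyl in place of hydrogen on a saturated chain carbon bound to an amine nitrogen and a saturated ring carbon. Among the measured compounds shown here, this is the same change as the one from compound 1 to compound 2, made on the same place, since the two place descriptions agree word for word; the cores on which it is made differ by methyl in place of hydrogen on an amine nitrogen.

For the measured compounds named here, the one measured instance of this change is the step from compound 1 to compound 2. On that basis the step from compound 3 to compound 4 in this assay is expected to be a 2.1-fold lower number from compound 3 to compound 4 (0.32 log units; beyond the scatter), of a similar size to the earlier one, with added uncertainty since the change has been seen only once and on the other core. Compound 4 is therefore estimated to give 3500 nM in this assay, with a range of 1500 nM to 8000 nM.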

Compound 4, inhibition constant: 703 nM
For compound 4 the middle estimate is 5.0-fold (0.70 log units) above the measured one; measured number outside the range, below it.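

In this assay the methyl on a saturated chain carbon bound to an amine nitrogen and a saturated ring carbon gives a 10-fold lower number from compound 3 to compound 4 (1.02 log units; beyond the scatter), so this change does not carry over at one size from the core of compound 1 to the core of compound 3: the same change on two cores in this assay, a 2.3-fold lower number (0.36 log units; beyond the scatter) from compound 1 to compound 2 and a 10-fold lower number (1.02 log units; beyond the scatter) from compound 3 to compound 4, 4.5-fold (0.65 log units) apart, beyond the scatter of two such steps The methyl on an amine nitrogen depends on the core in the same way, giving a 1.2-fold higher number from compound 2 to compound 4 (0.06 log units; within the scatter), so in this set the two changes do not simply add: the same change on two cores in this assay, a 5.2-fold higher number (0.72 log units; beyond the scatter) from compound 1 to compound 3 and a 1.2-fold higher number (0.06 log units; within the scatter) from compound 2 to compound 4, 4.5-fold (0.65 log units) apart, beyond the scatter of two such steps Both gaps come from the same four compounds and are one observation seen from two sides; the two changes together give a 2.0-fold lower number from compound 1 to compound 4 (0.30 log units; within the scatter), and nothing here shows why the steps differ or whether the same would hold on any other core.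

Open, as far as these compounds go, is whether an ethyl in place of either methyl, on the amine nitrogen or on the chain carbon, would depend on the core in the same way. Also open, from the compounds shown here alone, is how a dimethylamino group in place of the amine would behave with and without the methyl on the chain carbon.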